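A few compounds are considered here, and "the series" means these few. Any claim that something is new, unique, unknown or untested is made for them only; others in the source may bear on it.

Amino substituent variation on a shared pyridazinone-type core is not permitted—use: Amino substituent variation on the shared core

Amino substituent variation on the shared core

The series is followed in a functional assay on the whole organism (strain Wistar) for inhibition, with Rattus norvegicus as the target, read by paw edema, with stated times of 30 min and 3 h, at a dose of 25 mg/kg by the oral route; on this read-out higher numbers stand for a stronger effect at the one dose given and lower numbers for a weaker effect. Compound 1 `CCOc1c(NC)cnn(C)c1=O` gives -1.1% in this assay, and compound 2 `CCCNc1cnn(C)c(=O)c1OCC` gives 2%. Among the compounds with values here, of the two numbers so far, compound 2 holds the higher one, but the gap to compound 1 is within the scatter, so the two read as the same. Within the data shown here, the single step measured, a number 3.1 percentage points higher from compound 1 to compound 2 (within the scatter), is the only one that alters the amino group on the aromatic carbon, and it stays within the scatter.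

Compound 3 `CCOc1c(N(C)C)cnn(C)c1=O` is not yet measured. It differs from compound 2 as dimethylamino in place of propylamino on an aromatic carbon. Among the measured compounds shown here, this change again concerns the amino group on the same aromatic carbon, and the one step bearing on that position produced no effect beyond the scatter. Both measured compounds sit near zero inhibition in this assay.

No step beyond the scatter is therefore expected for compound 3 in this assay, the estimated change being a number 1 percentage points lower from compound 2 to compound 3 (within the scatter). Compound 3 is expected to give 1%, in the range -10% to 12%.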

Compound 3, a percentage reported as inhibition, in the whole organism at one dose (the size of the read-out at that dose, not a potency): 27.5%
The estimate for compound 3 lay 26.5 percentage points below the measured number; measured number above the stated range.
By their numbers in this assay, from the lowest: compounds 1 and 2 (each within the scatter of the next); then compound 3.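

In this assay the amino group on this aromatic carbon proves able to move the read-out, which the earlier pair did not show: dimethylamino in place of propylamino gives a number 25.5 percentage points higher from compound 2 to compound 3 (beyond the scatter), and methyl in place of hydrogen on the nitrogen gives a number 28.6 percentage points higher from compound 1 to compound 3 (beyond the scatter). Among the three compounds, the two steps beyond the scatter both lead to the dimethylamino compound, which has 0 hydrogen-bond donors in this group against 1 for propylamino, while ethyl in place of hydrogen on the chain carbon, with a number 3.1 percentage points higher from compound 1 to compound 2 (within the scatter), stays within the scatter, so here a second methyl on the nitrogen counts for more than a longer chain on it. No measurement at hand accounts for this difference, and the link between the donor count and the read-out remains only a coincidence of these three compounds.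

As far as these compounds go, whether the effect belongs to dimethylamino alone or extends to other groups with two substituents on the nitrogen, such as diethylamino, remains open, as does the behaviour of the unsubstituted amine at this position. With a single oral dose, these numbers give the size of the effect at that dose and say nothing about potency.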